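The source may report more compounds than this note shows. Statements on the series, on what has been measured and on what is new or still open speak of the compounds shown alone.

Measured compounds:
- compound 1, `C#CCSc1cnc2ccccc2c1[Se]CC#CCCl`: 1.8 ug/mL
- compound 2, `CSc1cnc2ccccc2c1[Se]CC#CCCl`: 1.7 ug/mL

Both compounds were tested in a functional assay on CCRF-CEM cells (Homo sapiens) for antiproliferative activity, with a stated time of 72 h; on this read-out higher numbers stand for weaker inhibition and lower numbers for stronger inhibition. For the measured compounds named here, compound 2 gives the lowest of the two numbers, but its nearest neighbour is compound 1, and the only measured step, a 1.1-fold lower number from compound 1 to compound 2 (0.02 log units; within the scatter), is within the scatter. The two values therefore stand as one pair without a difference of note.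

Compound 3, `CSc1cnc2ccccc2c1SCC#CCCl`, is the next compound. Its change from compound 2 is a group of 6 heavy atoms (4 carbon, 1 sulfur, 1 chlorine; no ring) in place of a group of 6 heavy atoms (4 carbon, 1 chlorine, 1 selenium; no ring), on an aromatic carbon. The group that leaves and the group that enters share the same chain with a triple bond and a chlorine at the end; the replacement concerns the atom that joins this chain to the aromatic carbon, a selenium in compound 2 and a sulfur in compound 3. Going by the values given here, no measured step touches this part of the molecule: the step from compound 1 to compound 2 altered the substituent bound to the sulfur on the other side of the core and left the number unchanged within the scatter. The expectation for compound 3 is therefore a step of a 1.5-fold higher number from compound 2 to compound 3 (0.17 log units; within the scatter), not clearly beyond the scatter, with a wide range. The estimated value for compound 3 in this assay is 2.5 ug/mL, between 1 ug/mL and 7 ug/mL.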

Compound 3, concentration for 50% inhibition: 2.5 ug/mL
For compound 3 middle estimate and measured number coincide at the digits printed; the range from low to high includes it.
By their numbers in this assay, from the lowest: compounds 2, 1 and 3 (each within the scatter of the next).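

Exchanging the selenium that joins the chlorine-ended chain to the aromatic carbon for a sulfur gives, in this assay, a 1.5-fold higher number from compound 2 to compound 3 (0.17 log units; within the scatter), so this read-out does not separate the two compounds. For the compounds shown here, this is the first measured step at this aromatic carbon, opposite the ring nitrogen, as the earlier step changed only the group on the sulfur of the shared core. Within this pair, then, selenium at this position is not needed for a number of this size, since the sulfur-linked compound 3 stands within the scatter of the selenium-linked compound 2, and no measurement available here bears on why the two atoms read alike in this assay.

The compounds shown leave open whether an oxygen atom or an amine nitrogen joining the same chain to the aromatic carbon would fit this picture, and whether a hydroxyl group in place of the chlorine at the chain end would shift the number. Also open, going by these compounds, is whether the same selenium-to-sulfur exchange would read alike in compound 1, with its ethynyl-bearing chain on the sulfur.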